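This account rests on a few compounds, and the source may have more. Where it says the series, first, only, none or still open, it means among the compounds named here.

Three compounds share one core and differ only at a nitrogen on an aromatic ring. Compound 1 `COc1cc(/C=C/C(=O)c2cccc(N)c2)ccc1O` carries hydrogen there, compound 2 `COc1cc(/C=C/C(=O)c2cccc(NC(=O)C(C)C)c2)ccc1O` an isopropylcarbonyl, and compound 3 `CCOC(=O)C(=O)Nc1cccc(C(=O)/C=C/c2ccc(O)c(OC)c2)c1` an (ethoxycarbonyl)carbonyl. In a functional assay on HUVEC cells (Homo sapiens) for inhibition, tested at 5 ug/mL (a higher number here means a stronger effect of the compound at the concentration tested, a lower number a weaker effect), compound 1 gives 50%, compound 2 gives 51% and compound 3 gives 45%. On these numbers compound 3 sits lowest of the three, with its nearest neighbour seen in a number 5 percentage points lower from compound 1 to compound 3 (within the scatter) and its furthest in a number 6 percentage points lower from compound 2 to compound 3 (within the scatter), both within the scatter.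

Compound 4 `CCCC(=O)Nc1cccc(C(=O)/C=C/c2ccc(O)c(OC)c2)c1` differs from compound 3 in one place: propyl in place of ethoxycarbonyl on a carbonyl carbon. The step that bears most directly on this change is the earlier one on the same carbonyl carbon, a number 6 percentage points lower from compound 2 to compound 3 (within the scatter), which stayed within the scatter; the steps of a number 1 percentage points higher from compound 1 to compound 2 (within the scatter) and a number 5 percentage points lower from compound 1 to compound 3 (within the scatter) were likewise within the scatter. Nothing among these three compounds shows a change at this nitrogen shifting the read-out beyond the scatter. Compound 4 is therefore expected to show a number 3 percentage points higher from compound 3 to compound 4 (within the scatter), no step beyond the scatter. The estimate for compound 4 is 48%, with a range from 38% to 58%.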

Compound 4, a percentage reported as inhibition, at one concentration (the size of the read-out at that concentration, not a potency): 57%
Beside the measured number, compound 4's estimate is 9 percentage points below it; low and high end bracket the measured number.
By their numbers in this assay, from the lowest: compounds 3, 1, 2 and 4 (each within the scatter of the next, the first and the last beyond it).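

Within the data shown here, at this carbonyl carbon, propyl in place of ethoxycarbonyl gives the first step beyond the scatter in this assay, with a number 12 percentage points higher from compound 3 to compound 4 (beyond the scatter) showing that a change at this nitrogen can move the read-out. The other new steps stay within the scatter, with a number 6 percentage points higher from compound 2 to compound 4 (within the scatter) and a number 7 percentage points higher from compound 1 to compound 4 (within the scatter) as well, so propylcarbonyl cannot be told apart from isopropylcarbonyl or from hydrogen on the nitrogen. Among the compounds that differ at this nitrogen, only the two carrying (ethoxycarbonyl)carbonyl and propylcarbonyl separate, and no other pair does.

From the compounds shown here alone, whether a longer chain, such as butyl, or an amine or carboxylic acid on this carbonyl carbon would move the read-out further stays open. No measured property of these compounds bears on this step, so what lies behind it remains unexplained.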